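Swapping Thiophene for Iodine on a Nucleoside Core

The compounds below may be only part of what the source reports. "The series", "measured", "known", "first", "only" and "open" are said of these compounds alone.

Compound 1, `COc1ncnc2c1c(-c1ccsc1)cn2[C@@H]1O[C@H](CO)[C@@H](O)[C@H]1O`: 90 nM
Compound 2, `COc1nc(N)nc2c1c(-c1ccsc1)cn2[C@@H]1O[C@H](CO)[C@@H](O)[C@H]1O`: > 20000 nM
Compound 3, `CNc1ncnc2c1c(-c1ccsc1)cn2[C@@H]1O[C@H](CO)[C@@H](O)[C@H]1O`: > 20000 nM

Among the measured compounds shown here, in a functional assay on K562 cells (Homo sapiens), read by MTT assay, with a stated time of 72 h (on this read-out higher numbers stand for weaker inhibition and lower numbers for stronger inhibition), compound 1 gives 90 nM, the only number among the three results. Compound 2 reaches only a limit of the assay, > 20000 nM. Compound 3 likewise sits at a limit, > 20000 nM. Both measured steps from compound 1 were large: an at least 220-fold higher number from compound 1 to compound 2 (2.34 log units; beyond the scatter) and an at least 220-fold higher number from compound 1 to compound 3 (2.34 log units; beyond the scatter). Compound 4, `COc1ncnc2c1c(I)cn2[C@@H]1O[C@H](CO)[C@@H](O)[C@H]1O`, differs from compound 1 by iodo in place of thiophen-3-yl on an aromatic carbon. Neither measured step touches that change; both alter a different place on the core, so they give no direct guide. Loss of the thiophen-3-yl group is nonetheless expected to weaken inhibition, a step of a 17-fold higher number from compound 1 to compound 4 (1.22 log units; beyond the scatter). Compound 4 is therefore estimated at 1500 nM, between 200 nM and 20000 nM.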

Compound 4, half-maximal inhibitory concentration: > 20000 nM
Compound 4 ended at the assay's limit (the forecaster's own chance of this, stated with the estimate: 25%); middle value at least 13-fold (1.12 log units) from the limit.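

Compound 1's thiophen-3-yl group proves to matter on this aromatic carbon: with iodo in its place there is an at least 220-fold higher number from compound 1 to compound 4 (2.34 log units; beyond the scatter). Among the compounds shown here, the earlier steps changed other places on the core, so this is the first sign that inhibition also depends on the group at this carbon. Compound 4 stands at a limit rather than a number, so the true size of the step stays unknown: the limit of > 20000 nM in this assay, at which 3 of the 4 values shown sit.

On these data alone, whether phenyl, furan-3-yl or a smaller group such as methyl would keep the inhibition of compound 1 remains open. So does the effect of an amine or a carboxylic acid on the thiophene ring.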